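Swapping the aryl group on the triazole of compound 2

The source may report more compounds than this note shows. Statements on the series, on what has been measured and on what is new or still open speak of the compounds shown alone.

Measured so far:
- compound 1, `COc1cc2c(Oc3ccc(NC(=O)c4cn(-c5ccccc5F)nn4)cc3F)ccnc2cc1OCCCN1CCCCC1`: 1290 nM
- compound 2, `COc1cc2c(Oc3ccc(NC(=O)c4cn(-c5ccccc5F)nn4)cc3F)ccnc2cc1OCCCN1CCC(C)CC1`: 130 nM

Both compounds were tested in a functional assay on MKN-45 cells (Homo sapiens) for cytotoxicity, read by MTT assay, with a stated time of 72 h; a higher number here means a weaker inhibitor, a lower number a stronger inhibitor. Of the two numbers, compound 2 stands at the lower end: the step of a 9.9-fold lower number from compound 1 to compound 2 (1.00 log units; beyond the scatter) sets it apart from compound 1 beyond the usual scatter.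

Compound 3, `COc1cc2c(Oc3ccc(NC(=O)c4cn(-c5c(Cl)cccc5Cl)nn4)cc3F)ccnc2cc1OCCCN1CCC(C)CC1`, has not yet been tested. It differs from compound 2 in one place: 2,6-dichlorophenyl in place of 2-fluorophenyl on an aromatic nitrogen. The methyl group on the saturated ring, which separates compound 1 from compound 2, is kept.

Among the compounds with values here, the only measured step, a 9.9-fold lower number from compound 1 to compound 2 (1.00 log units; beyond the scatter), concerns a different part of the molecule and therefore says nothing about what a change of the aryl group on the triazole nitrogen will do. Within the data shown here, with no measured step bearing on this change, the plain expectation for compound 3 is a number close to that of compound 2, with a step of a 1.2-fold higher number from compound 2 to compound 3 (0.06 log units; within the scatter) that stays within the usual scatter, in either direction. On that basis compound 3 is estimated at 150 nM in this assay, with a range from 40 nM to 600 nM that allows for a modest shift either way.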

Compound 3, half-maximal inhibitory concentration: 120 nM
Estimate against measurement, compound 3: 1.3-fold (0.10 log units) above; the range from low to high includes it.
By their numbers in this assay, from the lowest: compounds 3 and 2 (each within the scatter of the next); then compound 1.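

In this assay, within the data shown here, the step of a 1.1-fold lower number from compound 2 to compound 3 (0.03 log units; within the scatter) gives the first reading at this position: 2,6-dichlorophenyl can take the place of 2-fluorophenyl on the aromatic nitrogen, and the two compounds cannot be told apart in this read-out. The earlier compounds shown here both carried 2-fluorophenyl, so they showed only that the far end of the molecule matters, through the step of a 9.9-fold lower number from compound 1 to compound 2 (1.00 log units; beyond the scatter), which lies beyond the scatter, and nothing about this aryl group. Here the aryl group gains one heavy atom and two chlorine atoms replace the single fluorine, yet the number stays within the scatter, although no measurement shown here explains this result.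

Still open, on these data alone, is how far this freedom extends, since both groups are halogen-bearing phenyl rings: a plain phenyl, a pyridine ring or a small alkyl group such as methyl on the same nitrogen could read quite differently. As far as these compounds go, it is also open whether 2,6-dichlorophenyl would give a similar number without the methyl group on the saturated ring.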